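The source may report more compounds than this note shows. Statements on the series, on what has been measured and on what is new or still open speak of the compounds shown alone.

Measured compounds in a functional assay on HEL cells (Homo sapiens); a higher number here means that more compound is tolerated, a lower number that less compound is tolerated:

- compound 1, `CCOC(=O)NC(=O)NC1=CS(=O)(=O)O[C@@]12[C@@H](CO[Si](C)(C)C(C)(C)C)O[C@@H](n1cc(C)c(=O)n(C)c1=O)[C@@H]2O[Si](C)(C)C(C)(C)C`, gives 14000 nM
- compound 2, `CCOC(=O)CNC(=O)NC1=CS(=O)(=O)O[C@@]12[C@@H](CO[Si](C)(C)C(C)(C)C)O[C@@H](n1cc(C)c(=O)n(C)c1=O)[C@@H]2O[Si](C)(C)C(C)(C)C`, gives 13000 nM
- compound 3, `Cc1cn([C@@H]2O[C@H](CO[Si](C)(C)C(C)(C)C)[C@@]3(OS(=O)(=O)C=C3NCC(=O)C(N)=O)[C@H]2O[Si](C)(C)C(C)(C)C)c(=O)n(C)c1=O`, gives 14500 nM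

All three share the same core and differ only in the group carried on one nitrogen. Compound 3 has the highest of the three numbers, but the gaps are small: a 1.0-fold higher number from compound 1 to compound 3 (0.02 log units; within the scatter) and a 1.1-fold higher number from compound 2 to compound 3 (0.05 log units; within the scatter), so the three compounds are, in practice, indistinguishable in this assay. The step of a 1.1-fold lower number from compound 1 to compound 2 (0.03 log units; within the scatter) tells the same story.

Compound 4, `COC(=O)NC1=CS(=O)(=O)O[C@@]12[C@@H](CO[Si](C)(C)C(C)(C)C)O[C@@H](n1cc(C)c(=O)n(C)c1=O)[C@@H]2O[Si](C)(C)C(C)(C)C`, carries a different group on the same nitrogen: methoxycarbonyl in place of (carbamoylcarbonyl)methyl on an amine nitrogen. The group that enters is smaller than the group that leaves and has no hydrogen-bond donor, while the group that leaves has one.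

Three changes on this nitrogen have been measured, and none of them moved the number beyond the scatter. The change to compound 4 is of the same kind, at the same place, so no step beyond the scatter is expected in this assay, in either direction. Compound 4 is therefore estimated to give 14000 nM, with a range from 7000 nM to 28000 nM. This estimate means an expected step of a 1.0-fold lower number from compound 3 to compound 4 (0.02 log units; within the scatter), which is expected to lie within the scatter.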

Compound 4, half-maximal cytotoxic concentration: > 200000 nM
Compound 4: no number, only a limit (the forecaster's own chance of this, stated with the estimate: 10%); middle value at least 14-fold (1.15 log units) from the limit.
By their numbers in this assay, from the lowest: compounds 2, 1 and 3 (each within the scatter of the next). At a limit, above all of these: compound 4.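

The three earlier compounds made this nitrogen look indifferent to the group it carries in this assay, but methoxycarbonyl breaks that picture, with an at least 13-fold higher number from compound 3 to compound 4 (1.13 log units; beyond the scatter), an at least 15-fold higher number from compound 2 to compound 4 (1.18 log units; beyond the scatter) and an at least 14-fold higher number from compound 1 to compound 4 (1.15 log units; beyond the scatter). The last two steps are especially telling: compound 1 and compound 2 already have a carbonyl on this nitrogen, so replacing only what stands on that carbonyl, (ethoxycarbonyl)amino or ((ethoxycarbonyl)methyl)amino, with methoxy is enough to change how much compound the cells tolerate. The value of compound 4 is a limit of the assay and not a number: the limit of > 200000 nM in this assay, at which 1 of the 4 values shown sits.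

The compounds shown do not reveal whether the large step depends on methoxy itself or on a short group of this kind ending the carbonyl, and the cause of the step remains unknown. A longer chain such as propoxycarbonyl, or a free amine on the same nitrogen, would help to show how far the tolerance seen with compound 4 extends.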